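Moving the hydroxyl on the anilino group

The compounds below may be only part of what the source reports. "The series", "measured", "known", "first", "only" and "open" are said of these compounds alone.

Going by the values given here, compound 2 `Cn1nc(-c2ccnc(Nc3ccc(O)cc3)n2)c2ccccc21` holds the lowest number so far in a functional assay on HCT-116 cells (Homo sapiens) for antiproliferative activity, read by MTT assay, with a stated time of 72 h; a higher number here means a weaker inhibitor of growth, a lower number a stronger inhibitor of growth: compound 2 gives 8430 nM. Compound 1 `Clc1ccc(Nc2nc3ncccc3n2Cc2ccccc2)cc1` sits well above it; in this assay compound 1 gives 59500 nM, a gap beyond the scatter. Compound 3 `Cn1nc(-c2ccnc(Nc3cccc(O)c3)n2)c2ccccc21` carries 3-hydroxyphenyl in place of 4-hydroxyphenyl on a nitrogen on an aromatic ring. Among the compounds with values here, no pair of measured compounds isolates this change, so its direction is open; a shift no larger than the usual scatter is expected, either way. In this assay compound 3 is estimated at 10000 nM, within 3000 nM to 30000 nM. The step of a 1.2-fold higher number from compound 2 to compound 3 (0.07 log units; within the scatter) is expected to be small.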

Compound 3, concentration for 50% growth inhibition: 17200 nM
For compound 3 the middle estimate is 1.7-fold (0.24 log units) below the measured one; measured number inside the range.
By their numbers in this assay, from the lowest: compound 2; then compound 3; then compound 1.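

In this assay, going by these compounds alone, moving the hydroxyl gives a 2.0-fold higher number from compound 2 to compound 3 (0.31 log units; beyond the scatter) and is the only step so far that isolates a single change. With the same atoms joined differently, the position of the hydroxyl on the phenyl ring attached to the nitrogen alters growth inhibition modestly, and 4-hydroxyphenyl gives the lower number of this pair. Open, from the compounds shown here alone, is whether a methoxy group or an amine in place of the hydroxyl would keep the number of compound 2, or lower it. Nothing measured here bears on the cause of this step.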